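This account rests on a few compounds, and the source may have more. Where it says the series, first, only, none or still open, it means among the compounds named here.

Of the compounds shown here, two sharing the same core have been measured so far in a functional assay on T47D cells (Homo sapiens) for antiproliferative activity, with a stated time of 72 h; on this read-out lower numbers stand for stronger inhibition and higher numbers for weaker inhibition. Compound 1, with the structure `OCC#CCSc1cnc2ccccc2c1SCC#CCCl`, gives 5.3 ug/mL in this assay. Compound 2, with the structure `CSc1cnc2ccccc2c1[Se]CC#CCOC(=O)/C=C/c1ccccc1`, gives 4.3 ug/mL in this assay. Among these two numbers, that of compound 2 is the one that sits lowest, but its nearest neighbour is compound 1 and the gap separating them lies within the usual scatter of repeated measurements, so the two cannot really be told apart on this evidence.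

The next compound to be tested is compound 3, with the structure `CSc1cnc2ccccc2c1[Se]CC#CCOC(=O)c1ccccc1`. It differs from compound 2 in a single place: phenyl in place of 2-phenylethenyl on a carbonyl carbon. Within the data shown here, no earlier pair of measured compounds shows what such a swap does here, so there is no measured step to lean on. Among the measured compounds shown here, with only two values known and both so close, a step beyond the scatter is not expected; the change is estimated to give a step of a 1.0-fold higher number from compound 2 to compound 3 (0.02 log units; within the scatter) in this assay. Compound 3 is therefore estimated at 4.5 ug/mL in this assay, with a plausible range from 2 ug/mL to 10 ug/mL.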

Compound 3, concentration for 50% inhibition: 2.2 ug/mL
The estimate for compound 3 lay 2.0-fold (0.31 log units) above the measured number; the measured number falls inside the stated range.
By their numbers in this assay, from the lowest: compounds 3, 2 and 1 (each within the scatter of the next, the first and the last beyond it).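

In this assay, among these compounds, putting phenyl in place of 2-phenylethenyl on a carbonyl carbon gives a 2.0-fold lower number from compound 2 to compound 3 (0.29 log units; within the scatter) and is the first step measured at this position. It shows that removing the double bond outside the aromatic ring, while keeping a six-membered aromatic ring of carbon only on the carbonyl carbon, does not separate these two compounds on this read-out, although the step lies close to what the scatter can hide. No measurement at hand bears on what lies behind the size of this step.

From the compounds shown here alone, both groups compared here carry an aromatic ring, so it remains open whether a methyl, a cyclohexyl or a methoxyphenyl group on the same carbonyl carbon would give a step beyond the scatter. Going by these compounds, it is also open how far the ester link itself matters, for example if an amide stood in its place, and a repeat of compound 2 and compound 3 would help to settle whether the small step is real.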